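The compounds below may be only part of what the source reports. "The series", "measured", "known", "first", "only" and "open" are said of these compounds alone.

Values in a functional assay on the whole organism (strain Sprague-Dawley) for inhibition, with Rattus norvegicus as the target, with a stated time of 10 min (a lower number here means that less compound is needed, a higher number that more compound is needed for the effect), so far
- compound 1 `CCOc1ccc(C(=O)O)cc1-c1ncc(C(=O)O)c(=O)[nH]1` gives 25 mg/kg
- compound 2 `CCOC(=O)C(=O)Nc1ccc(OCC)c(-c2ncc(C(=O)O)c(=O)[nH]2)c1` gives 25 mg/kg

Compound 2 stands level with compound 1 in this assay and has no other measured neighbour. Compound 3 `CCOc1ccc(S(=O)(=O)N(C)C)cc1-c1ncc(C(=O)O)c(=O)[nH]1` differs from it thus dimethylsulfamoyl in place of ((ethoxycarbonyl)carbonyl)amino on an aromatic carbon and carries dimethylsulfamoyl in place of ((ethoxycarbonyl)carbonyl)amino on an aromatic carbon, para to an ethoxy group. Among the measured compounds shown here, the one measured step at this place is no change at the digits printed from compound 1 to compound 2 (within the scatter) and it alone bears on the change. No step beyond the scatter is therefore expected in this assay on this thin evidence. The estimated step is no change at the digits printed from compound 2 to compound 3 (within the scatter) on that single precedent. Compound 3 is expected at 25 mg/kg with an estimated range from 10 mg/kg to 60 mg/kg in this assay.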

Compound 3, dose for 50% inhibition: > 50 mg/kg
Compound 3: only a limit was reported; the forecaster's own chance of this, stated with the estimate: 10%; at least 2.0-fold (0.30 log units) between middle value and limit.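

In this assay compound 3 gives > 50 mg/kg, which is a limit of the assay and not a number. With dimethylsulfamoyl para to an ethoxy group, the reading is no longer simply level: the change gives an at least 2.0-fold higher number from compound 2 to compound 3 (0.30 log units; that floor lies within the scatter) and, against carboxy, an at least 2.0-fold higher number from compound 1 to compound 3 (0.30 log units; that floor lies within the scatter). This position may therefore not be indifferent to its substituent, although neither floor alone establishes a real difference.

From the compounds shown here alone, how far the value of compound 3 lies past its limit remains open. An unsubstituted sulfonamide or an amine at this place would help show whether the sulfonyl unit or its two methyl groups matter.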